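From Acetyl to Cyano on a Shared Core

This account rests on a few compounds, and the source may have more. Where it says the series, first, only, none or still open, it means among the compounds named here.

Compound 3 `COc1ccc(C(C)=O)cc1CSc1nc2cc(NC(=O)C3CC3)ccc2n1C(C)C` is one of three close relatives built on one shared core. In an assay on isolated protein for inhibition of Gonadotropin-releasing hormone receptor (Rattus norvegicus) (on this read-out lower numbers stand for stronger inhibition and higher numbers for weaker inhibition), compound 3 reaches only the limit of the assay, > 10000 nM. Compound 1 `Cc1cccc(CSc2nc3cc(NC(=O)C4CC4)ccc3n2C(C)C)c1` also stops at a limit in this assay, giving > 10000 nM. Compound 2 `CC(C)n1c(SCc2ccccc2Cl)nc2cc(NC(=O)C3CC3)ccc21` likewise gives a limit in this assay, > 10000 nM. Among the compounds with values here, the one comparison among them, a step that the two limits leave unreadable from compound 1 to compound 2, cannot be read, and the limit of > 10000 nM in this assay, at which 3 of the 3 values shown sit, shows every value sitting at the same edge. Compound 4 `COc1ccc(C#N)cc1CSc1nc2cc(NC(=O)C3CC3)ccc2n1C(C)C` differs from compound 3 by cyano in place of acetyl on an aromatic carbon, a cyano in place of acetyl on an aromatic carbon. Within the data shown here, no measured step bears on this change, so for compound 4 the expected outcome in this assay is again a limit rather than a readable number. The estimate for compound 4 is 12000 nM, between 3000 nM and 40000 nM, meaning an expected step that the limit leaves unreadable from compound 3 to compound 4.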

Compound 4, half-maximal inhibitory concentration: > 10000 nM
Compound 4 ended at the assay's limit; the forecaster's own chance of this, stated with the estimate: 75%; the middle value is on the limit's open side.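

Compound 4 ends at a limit, as do compound 1, compound 2 and compound 3, and no step among these compounds can be read. In this assay the compounds shown leave open whether any change on the shared core can give a readable value.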